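Notes on compound 4, a methoxymethyl variant of compound 2

The compounds below may be only part of what the source reports. "The series", "measured", "known", "first", "only" and "open" are said of these compounds alone.

Measured in an assay on HEK293 cells for agonist activity at probable G-protein coupled receptor 34 (Mus musculus), with a stated time of 1 h; a higher number here means a larger maximal response, a lower number a smaller maximal response:
compound 1 `CCCCCCCC/C=C\CCCCCCCC(=O)OC[C@H](COC)OP(=O)(O)OC[C@H](N)C(=O)O` gives 7.5%
compound 2 `N[C@@H](COP(=O)(O)OCCOC(=O)CCc1ccccc1OCc1cccc(Oc2ccccc2)c1)C(=O)O` gives 12.4%
compound 3 `C[C@H](COP(=O)(O)OC[C@H](N)C(=O)O)OC(=O)CCc1ccccc1OCc1cccc(Oc2ccccc2)c1` gives 12%

Compound 2 carries the largest of the three numbers, yet neither gap is beyond the scatter: compound 3 lies closest, compound 1 furthest, both within it. Going by these compounds, compound 4 `COC[C@H](COC(=O)CCc1ccccc1OCc1cccc(Oc2ccccc2)c1)OP(=O)(O)OC[C@H](N)C(=O)O` is untested in this assay. It differs from compound 2 by methoxymethyl in place of hydrogen on a saturated chain carbon bound to an oxygen on an unsaturated carbon and a saturated chain carbon. For the measured compounds named here, the one measured step bearing on it is a number 0.4 percentage points lower from compound 2 to compound 3 (within the scatter), a small group on the same chain region with no effect beyond the scatter. Compound 1, which also bears a methoxymethyl group among many other differences, gives a value within the scatter of compound 2. No step beyond the scatter is therefore expected: the estimate is a number 2.4 percentage points lower from compound 2 to compound 4 (within the scatter). Compound 4 is expected at 10%, range 3% to 18%.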

Compound 4, largest response reached (Emax), in percent of the reference or control that the assay uses: 13.5%
Compound 4: the middle estimate sits 3.5 percentage points below what was measured; measured number inside the range.
By their numbers in this assay, from the lowest: compounds 1, 3, 2 and 4 (each within the scatter of the next).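

On a saturated chain carbon bound to an oxygen on an unsaturated carbon and a saturated chain carbon, methoxymethyl in place of hydrogen adds 3 heavy atoms, and this assay shows a number 1.1 percentage points higher from compound 2 to compound 4 (within the scatter) as the outcome. For the compounds shown here, this place therefore accepts an ether-bearing group without a step beyond the scatter, which the earlier compounds did not show. No available measurement accounts for this result. Going by these compounds, whether an amine, a carboxylic acid or a longer alkoxy chain at this place would give a step beyond the scatter remains open.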